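Methoxy for hydrogen: a repeated step in the series

The compounds below may be only part of what the source reports. "The series", "measured", "known", "first", "only" and "open" are said of these compounds alone.

Compound 1 `COc1ccc(C(=O)c2cc(OC)c(OC)c(OC)c2)cc1NC(=O)/C=C/c1cc(OC)c(OC)c(OC)c1` and compound 2 `COc1ccc(C(=O)c2cc(OC)c(OC)c(OC)c2)cc1NC(=O)/C=C/c1ccc(F)cc1` share a core and differ by 3,4,5-trimethoxyphenyl in place of 4-fluorophenyl on a double-bonded chain carbon bound to a double-bonded chain carbon. In a functional assay on PC-3 cells (Homo sapiens) for cytotoxicity, read by MTT assay, with a stated time of 72 h (on this read-out lower numbers stand for stronger inhibition and higher numbers for weaker inhibition), compound 1 gives 3900 nM, and compound 2 gives 3200 nM; the step between them is a 1.2-fold lower number from compound 1 to compound 2 (0.09 log units; within the scatter). Compound 3 `COc1cc(/C=C/C(=O)Nc2cc(C(=O)c3cc(OC)c(OC)c(OC)c3)ccc2OC)ccc1F` carries methoxy in place of hydrogen on an aromatic carbon; in this assay compound 3 gives 14100 nM, the step running a 4.4-fold higher number from compound 2 to compound 3 (0.64 log units; beyond the scatter), while against compound 1 it reads a 3.6-fold higher number from compound 1 to compound 3 (0.56 log units; beyond the scatter). Compound 4 `COc1cc(C(=O)c2cc(OC)c(OC)c(OC)c2)cc(NC(=O)/C=C/c2cc(OC)c(OC)c(OC)c2)c1OC` has not been measured in this assay. It arises from compound 1 by methoxy in place of hydrogen on an aromatic carbon, the same kind of change as from compound 2 to compound 3, though the surroundings differ: in compound 3 the new group sits ortho to a fluoro group and meta to a large group, in compound 4 ortho to a methoxy group and meta to two large groups. Among the measured compounds shown here, only one measured instance of the change exists, so the expectation rests on it alone. The step expected from this change is a 3.1-fold higher number from compound 1 to compound 4 (0.49 log units; beyond the scatter), because a 4.4-fold higher number from compound 2 to compound 3 (0.64 log units; beyond the scatter) went beyond the scatter. Compound 4 is accordingly estimated at 12000 nM, within a range of 5000 nM to 30000 nM.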

Compound 4, half-maximal inhibitory concentration: 4800 nM
Beside the measured number, compound 4's estimate is 2.5-fold (0.40 log units) above it; the measured number lies below the stated range.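

In this assay, methoxy in place of hydrogen on an aromatic carbon gives a 1.2-fold higher number from compound 1 to compound 4 (0.09 log units; within the scatter), so the step seen on the fluorinated core does not carry over to the core of compound 1. Set side by side, the two instances of this change differ: the same change on two cores in this assay, a 4.4-fold higher number (0.64 log units; beyond the scatter) from compound 2 to compound 3 and a 1.2-fold higher number (0.09 log units; within the scatter) from compound 1 to compound 4, 3.6-fold (0.55 log units) apart, beyond the scatter of two such steps This shows that in this series the step measured on one core cannot simply be transferred to another, but two instances do not show which difference between the cores goes with the gap, nor what the change would do on a third core.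

The compounds shown leave open whether the same split between the two cores would appear with another group on that aromatic carbon, such as a hydroxy group, an amine or a chlorine atom. They also leave open whether replacing the 3,4,5-trimethoxyphenyl or 4-fluorophenyl group with a different ring would change how the methoxy step reads.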